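This account rests on a few compounds, and the source may have more. Where it says the series, first, only, none or still open, it means among the compounds named here.

In a functional assay on HCT-15 cells (Homo sapiens) (a higher number here means that more compound is needed for the effect, a lower number that less compound is needed), compound 1 `COc1cc(C2OC(c3ccc(N(C)C)cc3)=NN2C(C)=O)cc(OC)c1OC` gives 0.033 uM. Compound 2 `COc1cc(C2OC(c3ccccc3N(C)C)=NN2C(C)=O)cc(OC)c1OC`, with 2-(dimethylamino)phenyl in place of 4-(dimethylamino)phenyl, gives 65 uM. That change is a 2000-fold higher number from compound 1 to compound 2 (3.29 log units; beyond the scatter). Compound 3 `COC(=O)N1N=C(c2ccc(N(C)C)cc2)OC1c1cc(OC)c(OC)c(OC)c1`, with methoxy in place of methyl on a carbonyl carbon, gives 40 uM. That change is a 1200-fold higher number from compound 1 to compound 3 (3.08 log units; beyond the scatter). Among the measured compounds shown here, compound 3 therefore stands within the scatter of compound 2 and far from compound 1, at the high end of the numbers so far.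

Compound 4 `COc1cc(C2OC(c3ccc(N(C)C)cc3)=NN2C(=O)CN=[N+]=[N-])cc(OC)c1OC` has azidomethyl in place of methoxy on a carbonyl carbon, (azidomethyl in place of methoxy on a carbonyl carbon). It keeps the 4-(dimethylamino)phenyl of compound 3. The measured step that bears most directly on this change is a 1200-fold higher number from compound 1 to compound 3 (3.08 log units; beyond the scatter), made at the same carbonyl carbon. Compound 4 gives up the methoxy of that step and, like compound 1, has a carbon attached there. The step to compound 2 lies elsewhere and shows only how large a single change can be among these compounds. For the measured compounds named here, no azidomethyl compound has been measured, so how much of the gap is recovered remains open. The expected step is a 100-fold lower number from compound 3 to compound 4 (2.00 log units; beyond the scatter), large and toward a lower number, though probably short of the full return. Compound 4 is estimated at 0.4 uM, with an expected range from 0.03 uM to 10 uM.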

Compound 4, concentration for half-maximal effect: 0.15 uM
Beside the measured number, compound 4's estimate is 2.7-fold (0.43 log units) above it, and the stated range covers the measured number.
By their numbers in this assay, from the lowest: compound 1; then compound 4; then compounds 3 and 2 (each within the scatter of the next).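

In this assay the position on the carbonyl carbon proves far less restrictive than compound 3 alone suggested: azidomethyl in place of methoxy brings a 270-fold lower number from compound 3 to compound 4 (2.43 log units; beyond the scatter) and so recovers most of the large loss seen with methoxy. Azido in place of hydrogen on the saturated chain carbon is a much smaller change, at a 4.5-fold higher number from compound 1 to compound 4 (0.66 log units; beyond the scatter) and still beyond the scatter, which shows that this position accepts a group extending well past methyl at only a modest cost, whereas the methoxy of compound 3 costs far more, with a 1200-fold higher number from compound 1 to compound 3 (3.08 log units; beyond the scatter) in the same assay. Nothing available explains why azidomethyl is so much better accepted here than methoxy.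

The compounds shown leave open whether the azido group itself matters or whether another group on the same chain carbon would serve as well, such as an amine in aminomethyl, a hydroxyl in hydroxymethyl, or a longer chain such as propyl in place of azidomethyl. They also leave open whether azidomethyl would change the outcome with 2-(dimethylamino)phenyl in place of 4-(dimethylamino)phenyl, a change that on its own gave a 2000-fold higher number from compound 1 to compound 2 (3.29 log units; beyond the scatter) in the methyl series.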